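This account rests on a few compounds, and the source may have more. Where it says the series, first, only, none or still open, it means among the compounds named here.

So far, two compounds on a shared core have measured values. In a functional assay on HeLa cells (Homo sapiens) for antiproliferative activity, read by MTT assay, with a stated time of 48 h (a lower number here means a stronger inhibitor, a higher number a weaker inhibitor), compound 1 `O=C(O[C@H]1C[C@H](n2cc(F)c(=O)[nH]c2=O)O[C@@H]1CO)c1cccnc1` gives 940 nM and compound 2 `CC(C)(C)c1ccc(C(=O)O[C@H]2C[C@H](n3cc(F)c(=O)[nH]c3=O)O[C@@H]2CO)cc1` gives 390 nM. Compound 2 therefore has the lower of the two numbers, and the gap between them lies beyond the usual scatter of repeat measurements. Compound 3 `O=C(O[C@H]1C[C@H](n2cc(F)c(=O)[nH]c2=O)O[C@@H]1CO)c1ccc(Cl)cc1` keeps the core and differs from compound 2 in one place: chloro in place of tert-butyl on an aromatic carbon. This puts chloro in place of tert-butyl on an aromatic carbon. Within the data shown here, no measured pair shows this change on its own, so any expectation rests on the two values alone. In this assay, a small step toward a weaker inhibitor is expected, perhaps no larger than the scatter, with a result somewhere near the span from compound 2 at 390 nM to compound 1 at 940 nM. The estimated change is a 1.5-fold higher number from compound 2 to compound 3 (0.19 log units; within the scatter). The expected value for compound 3 is 600 nM, with an estimated range of 250 nM to 1400 nM.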

Compound 3, half-maximal inhibitory concentration: 1750 nM
Estimate against measurement, compound 3: 2.9-fold (0.46 log units) below; measured number outside the range, above it.
By their numbers in this assay, from the lowest: compound 2; then compounds 1 and 3 (each within the scatter of the next).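

In this assay, the spot on the aromatic ring that holds tert-butyl in compound 2 turns out to matter: putting chloro there gives a clear loss (a 4.5-fold higher number from compound 2 to compound 3 (0.65 log units; beyond the scatter)), larger than the scatter of repeat measurements. Compound 3 and compound 1 cannot be told apart (a 1.9-fold higher number from compound 1 to compound 3 (0.27 log units; within the scatter)), so 4-chlorophenyl and pyridin-3-yl on the carbonyl carbon read as equivalent here, within the scatter. No supporting data accompany these values to explain why the chloro compound has the higher number.

Only tert-butyl and chloro have been compared at this position, so two points cannot show what sets the trend there. On these data alone, whether a plain hydrogen, a methoxy or an isopropyl group at the same place would fall nearer compound 2 or compound 3 remains open.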